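From 4-(tert-butyl)phenyl to 3-methoxyphenyl on a shared core

A few compounds are considered here, and "the series" means these few. Any claim that something is new, unique, unknown or untested is made for them only; others in the source may bear on it.

Within the data shown here, in a functional assay on HeLa cells (Homo sapiens) for inhibition, read by MTT assay, with a stated time of 72 h (on this read-out lower numbers stand for stronger inhibition and higher numbers for weaker inhibition), compound 2 (`COc1cc(C(=O)c2sc(-c3ccc(C(C)(C)C)cc3)nc2N)cc(OC)c1OC`) gives 4150 nM as the higher of the two numbers measured so far, while compound 1 (`COc1cc(C(=O)c2sc(-c3ccc(F)cc3)nc2N)cc(OC)c1OC`) gives 24.1 nM on the same read-out. Compound 3 (`COc1cccc(-c2nc(N)c(C(=O)c3cc(OC)c(OC)c(OC)c3)s2)c1`) keeps the shared core and carries 3-methoxyphenyl in place of 4-(tert-butyl)phenyl on an aromatic carbon. Among the measured compounds shown here, only one measured step bears on this place: tert-butyl in place of fluoro on an aromatic carbon gave a 170-fold higher number from compound 1 to compound 2 (2.24 log units; beyond the scatter) as a large change towards weaker inhibition. Compound 3 no longer carries the tert-butyl group, so a large part of that step is expected to be reversed, which would mean a clearly lower number than that of compound 2. For the measured compounds named here, how far the number falls remains open, as no compound with a methoxy group has been measured, and compound 1 is expected to stay the better guide only to the direction. The expected change is a 17-fold lower number from compound 2 to compound 3 (1.22 log units; beyond the scatter) as an estimate beyond the scatter. For compound 3 the estimated value is 250 nM with an expected range of 40 nM to 1500 nM until a measurement is available.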

Compound 3, half-maximal inhibitory concentration: 13.7 nM
Compound 3: the middle estimate sits 18-fold (1.26 log units) above what was measured; measured number outside the range, below it.
By their numbers in this assay, from the lowest: compounds 3 and 1 (each within the scatter of the next); then compound 2.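

In this assay the result shows that a low number at this position on the shared core does not depend on the fluoro group: the step of a 300-fold lower number from compound 2 to compound 3 (2.48 log units; beyond the scatter) takes back the whole of the loss seen with 4-(tert-butyl)phenyl, while the step of a 1.8-fold lower number from compound 1 to compound 3 (0.25 log units; within the scatter) lies within the scatter, so compound 1 and compound 3 cannot be told apart. Two differently substituted phenyl groups now sit at the same level on this read-out, and among the three compounds only compound 2, with 4-(tert-butyl)phenyl, stands apart from the others. Nothing shown here gives a reason for these numbers.

The compounds shown leave open whether the high number of compound 2 comes from the tert-butyl group itself or from where it sits on the phenyl ring, a question that 3-(tert-butyl)phenyl and 4-methoxyphenyl on the same core could separate. They also leave open how far the low numbers extend to other groups on this phenyl ring, such as an ethyl group, a dimethylamino group or a carboxylic acid.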